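Swapping a Pyrazole Amide for a Methylpyridine

The compounds below may be only part of what the source reports. "The series", "measured", "known", "first", "only" and "open" are said of these compounds alone.

Of the compounds shown here, two have so far been measured in an ADME assay on microsomes from liver (Homo sapiens) for metabolic stability, read by LC-MS, using NADPH, with stated times of 5 min and 30 min, tested at 1 uM; a higher number here means faster removal of the compound, a lower number slower removal. Compound 1, `CN(C)C(=O)c1cc(-c2cnc(NCc3c(F)ccc4c3CCO4)c3cn[nH]c(=O)c23)n(C)n1`, gives 21 mL.min-1.g-1 in this assay. Compound 2, `O=C1Oc2ccccc2CN1c1cnc(NCc2c(F)ccc3c2CCO3)n2cnnc12`, gives 24 mL.min-1.g-1 in this assay. These two numbers lie within the usual scatter of repeated measurements, so neither compound stands apart from the other; compound 1 sits at one end of a pair that is, for practical purposes, a single level.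

The next compound, compound 3, `Cc1ncccc1-c1cnc(NCc2c(F)ccc3c2CCO3)c2cn[nH]c(=O)c12`, has not yet been measured. It differs from compound 1 in one place: 2-methylpyridin-3-yl in place of 3-(dimethylcarbamoyl)-1-methyl-1H-pyrazol-5-yl on an aromatic carbon. For the measured compounds named here, the two measured compounds differ in many places at once, so there is no precedent for how a change of this kind moves the number in this assay.

Going by the values given here, with the measured values close together and no comparable step to lean on, the expectation is that compound 3 stays near the measured level, and the estimated step of a 1.4-fold higher number from compound 1 to compound 3 (0.15 log units; within the scatter) is small, not clearly beyond the scatter in either direction. Compound 3 is therefore expected to give about 30 mL.min-1.g-1 in this assay, with a range from 12 mL.min-1.g-1 to 75 mL.min-1.g-1.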

Compound 3, intrinsic clearance in microsomes: 41 mL.min-1.g-1
The estimate for compound 3 lay 1.4-fold (0.14 log units) below the measured number; the range from low to high includes it.
By their numbers in this assay, from the lowest: compounds 1, 2 and 3 (each within the scatter of the next).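

For the compounds shown here, this is the first step that changes only one place. On an aromatic carbon of the shared core, 2-methylpyridin-3-yl replaces 3-(dimethylcarbamoyl)-1-methyl-1H-pyrazol-5-yl, and this assay records a 2.0-fold higher number from compound 1 to compound 3 (0.29 log units; within the scatter). So at this position, a group of 7 heavy atoms with one hydrogen-bond acceptor can stand in for one of 11 heavy atoms with three acceptors without taking the number beyond the scatter of repeated measurements, although a single step cannot show whether a small real difference lies within that scatter. No measurement shown here explains the result.

The swap changes the ring, its methyl placement and the amide all at once, so the compounds shown cannot assign any part of the step to any one of these features. Also open, as far as these compounds go, is how the number would respond to a quite different kind of group on this aromatic carbon, such as an amine or a carboxylic acid, since the shared core has so far carried only these two aromatic rings here.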